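The source may report more compounds than this note shows. Statements on the series, on what has been measured and on what is new or still open speak of the compounds shown alone.

For the measured compounds named here, compound 2 `O=C(NCCCCc1ccccc1)c1cccc(C2SCC(=O)N2c2ccccn2)c1` gives the lowest of the two numbers so far in a functional assay on HOS-TE85 cells (Homo sapiens) for inhibition, read by CCK-8 assay, with a stated time of 72 h (on this read-out lower numbers stand for stronger inhibition and higher numbers for weaker inhibition), with 19.7 nM; compound 1 `O=C(NCCCCn1cccn1)c1cccc(C2SCC(=O)N2c2ccccn2)c1` gives 60.3 nM, and the step of a 3.1-fold lower number from compound 1 to compound 2 (0.49 log units; beyond the scatter) concerns only the end of the chain. Compound 3 `COc1ccc(F)cc1N1C(=O)CSC1c1cccc(C(=O)NCCCCc2ccccc2)c1` instead changes the ring nitrogen: 5-fluoro-2-methoxyphenyl in place of pyridin-2-yl on an amide-type nitrogen in a ring. Going by the values given here, no measured step touches this position, so there is nothing to set a direction, and the expected step of a 1.3-fold higher number from compound 2 to compound 3 (0.10 log units; within the scatter) is left near zero with a wide range. Compound 3 is therefore estimated at 25 nM, between 8 nM and 80 nM.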

Compound 3, half-maximal inhibitory concentration in the HOS-TE85 assay: 8.8 nM
Estimate against measurement, compound 3: 2.8-fold (0.45 log units) above, and the stated range covers the measured number.
By their numbers in the HOS-TE85 assay, from the lowest: compound 3; then compound 2; then compound 1.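

In the HOS-TE85 assay the position on the amide-type nitrogen in a ring responds to this change, with a 2.2-fold lower number from compound 2 to compound 3 (0.35 log units; beyond the scatter), so a ring of carbon only serves there and the nitrogen of pyridin-2-yl is not required. In a physicochemical assay for solubility, read by turbidimetry, measured as kinetic solubility, at pH 6.8 (a higher number here means a more soluble compound, a lower number a less soluble compound), compound 2 gives 20000 nM and compound 3 gives 10000 nM, two values within the usual scatter of each other. Nothing available explains the shift in activity. On these data alone, the fluorine and the methoxy group enter together, so their separate shares stay open, as does how a chlorine or an amine on that ring would read.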